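Clearance notes: fluoro in place of trifluoromethyl

A few compounds are considered here, and "the series" means these few. Any claim that something is new, unique, unknown or untested is made for them only; others in the source may bear on it.

Measured compounds:
compound 1 `COc1cnc(-c2ccccn2)nc1N(C)C1CCCC1`: > 1000 mL/min/kg, a limit of the assay
compound 2 `COc1cnc(-c2ccccn2)nc1NCc1ccccc1C(F)(F)F`: 555 mL/min/kg
compound 3 `COc1cnc(-c2ccccn2)nc1C1CCCC1`: > 1000 mL/min/kg, a limit of the assay

Among the measured compounds shown here, in an in vitro ADME assay on microsomes from liver (Rattus norvegicus) for metabolic stability, read by LC-MS, tested at 0.05 uM (on this read-out higher numbers stand for fast clearance and lower numbers for slow clearance), compound 2 holds the only value that is a number; the other two values are limits. They sit at the limit of > 1000 mL/min/kg in this assay, at which 2 of the 3 values shown sit. The step that the two limits leave unreadable from compound 1 to compound 3 therefore has no readable size. Compound 4 `COc1cnc(-c2ccccn2)nc1NCc1ccccc1F` differs from compound 2 by fluoro in place of trifluoromethyl on an aromatic carbon. For the measured compounds named here, no measured step bears on this change, so nothing is expected beyond the scatter, and the step from compound 2 to compound 4 is estimated at a 1.0-fold lower number from compound 2 to compound 4 (0.00 log units; within the scatter). Compound 4 is thus expected to give about 550 mL/min/kg in this assay, with a range from 250 mL/min/kg to 1000 mL/min/kg.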

Compound 4, clearance: 413 mL/min/kg
Estimate against measurement, compound 4: 1.3-fold (0.12 log units) above; low and high end bracket the measured number.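

In this assay, fluoro in place of trifluoromethyl, on an aromatic carbon ortho to a large group, gives a 1.3-fold lower number from compound 2 to compound 4 (0.13 log units; within the scatter). Going from 4 heavy atoms to 1 at this place therefore does not separate the two compounds in clearance. This is the first step of readable size in the series, as the only earlier step, between compound 1 and compound 3, cannot be read: the limit of > 1000 mL/min/kg in this assay, at which 2 of the 4 values shown sit.

The compounds shown leave open how a chloro, a methoxy or a nitrile on this carbon would read. Going by these compounds, whether a hydrogen there would stay as close to either halogen-bearing compound also remains open.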